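The source may report more compounds than this note shows. Statements on the series, on what has been measured and on what is new or still open speak of the compounds shown alone.

Going by the values given here, in an ADME assay on microsomes from liver (Rattus norvegicus) for metabolic stability, using NADPH, with a stated time of 10 min (on this read-out higher numbers stand for a more stable compound and lower numbers for a less stable compound), three compounds on a shared core have numbers so far. Compound 1 `CN(C[C@H]1Cc2c(cccc2N2C[C@H]3CNC[C@H]3C2)CN1)[C@H]1CCCc2cccnc21` gives 38.1% on this read-out. Compound 2 `CN(C)[C@H]1CCN(c2cccc3c2C[C@H](CN(C)[C@H]2CCCc4cccnc42)NC3)C1` gives 4.55% and compound 3 `CN(C)[C@@H]1CCN(c2cccc3c2C[C@H](CN(C)[C@H]2CCCc4cccnc42)NC3)C1` gives 3.88% on the same read-out. Compound 3 thus sits level with compound 2 at the low end of the numbers, far under compound 1. Two large steps read a number 33.6 percentage points lower from compound 1 to compound 2 (beyond the scatter) and a number 34.2 percentage points lower from compound 1 to compound 3 (beyond the scatter) and each swaps the group on an aromatic carbon. A third step reads a number 0.7 percentage points lower from compound 2 to compound 3 (within the scatter) and it goes with the fact that compounds 2 and 3 differ only in the configuration as drawn in this small series.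

Compound 4 `CN(C)C1CCN(c2cccc3c2C[C@H](CN(C)[C@H]2CCCc4cccnc42)NC3)CC1` has not been measured yet. It carries 4-(dimethylamino)piperidin-1-yl in place of 3-(dimethylamino)pyrrolidin-1-yl on an aromatic carbon. In counted terms the change reads 4-(dimethylamino)piperidin-1-yl in place of 3-(dimethylamino)pyrrolidin-1-yl on an aromatic carbon and the place stays the same. The two large steps away from compound 1 both end on a group with a single ring, and compound 4 also has a group with a single ring. No step beyond the scatter is therefore expected in this assay for this swap, with compound 3 at 3.88% as the anchor. The estimated step is a number 2.1 percentage points higher from compound 3 to compound 4 (within the scatter) and it is expected to stay small. Compound 4 is expected at an estimated 6% with a range from 1% to 18% on this read-out.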

Compound 4, percent of the compound remaining: 52.4%
Estimate against measurement, compound 4: 46.4 percentage points below; measured number above the stated range.
By their numbers in this assay, from the lowest: compounds 3 and 2 (each within the scatter of the next); then compound 1; then compound 4.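

In this assay, this aromatic carbon proves highly sensitive to which ring it carries: 4-(dimethylamino)piperidin-1-yl in place of 3-(dimethylamino)pyrrolidin-1-yl gives a number 48.5 percentage points higher from compound 3 to compound 4 (beyond the scatter) and a number 47.9 percentage points higher from compound 2 to compound 4 (beyond the scatter). The earlier compounds shown here had tied a group with a single ring to low numbers, but the single six-membered ring also exceeds the group with two five-membered rings, with a number 14.3 percentage points higher from compound 1 to compound 4 (beyond the scatter). Both drawn forms of the five-membered group sit low, so the jump does not depend on one particular form, and this comparison is clean for the following reason: the fact that compounds 2 and 3 differ only in the configuration as drawn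

The swap changes the ring size, the place of the dimethylamino group on the ring and the presence of the defined stereocentre all at once, and the compounds shown cannot separate these three changes. Also open, going by these compounds, is how the number would respond to a piperidine ring carrying a primary amine instead of the dimethylamino group, or to a morpholine ring on the same aromatic carbon.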